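This account rests on a few compounds, and the source may have more. Where it says the series, first, only, none or still open, it means among the compounds named here.

Measured compounds:
- Compound 1 `COC[C@H](C1CC1)n1cc(Cl)nc(Nc2cc(C)c(OC)nc2C)c1=O`: 24%
- Compound 2 `COC[C@@H](C1CC1)n1cc(Cl)nc(Nc2cc(C)c(OC)nc2C)c1=O`: 13%

In an ADME assay on microsomes from liver (Rattus norvegicus) for metabolic stability, read by HPLC, with a stated time of 10 min, tested at 3 uM (on this read-out lower numbers stand for a less stable compound and higher numbers for a more stable compound), compound 2 holds the lower of the two numbers at 13%, while compound 1 reaches 24%. The next structure, compound 3 `CC[C@H](C1CC1)n1cc(Cl)nc(Nc2cc(C)c(OC)nc2C)c1=O`, keeps the shared core of compound 2 but carries 1-cyclopropylpropyl in place of 1-cyclopropyl-2-methoxyethyl on an aromatic nitrogen.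

For the measured compounds named here, only one measured step is available, a number 11 percentage points lower from compound 1 to compound 2 (beyond the scatter), a modest one. It does not test this swap, since those two compounds differ solely in drawn configuration (the fact that compounds 1 and 2 differ only in the configuration as drawn). It therefore gives a rough sense of how far a small change can move this assay, but no direction. With no firm direction, no step beyond the usual scatter is expected, though a slight rise is possible. The expected step is a number 5 percentage points higher from compound 2 to compound 3 (within the scatter). For compound 3 the estimate is 18%, with an expected range from 6% to 40%.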

Compound 3, percent of the compound remaining: 5%
Estimate against measurement, compound 3: 13 percentage points above; measured number outside the range, below it.
By their numbers in this assay, from the lowest: compounds 3 and 2 (each within the scatter of the next); then compound 1.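

In this assay, this position now has its first test of a change in the group itself rather than in its drawn configuration. Measured against one partner, 1-cyclopropylpropyl in place of 1-cyclopropyl-2-methoxyethyl gives a number 8 percentage points lower from compound 2 to compound 3 (within the scatter), while methyl in place of methoxy, measured against the other, gives a number 19 percentage points lower from compound 1 to compound 3 (beyond the scatter), so neither comparison shows a gain in stability from this change. How much the change appears to cost depends on the starting compound, and those two starting compounds are closely related: the fact that compounds 1 and 2 differ only in the configuration as drawn

On these data alone, it remains open what the opposite drawn configuration of 1-cyclopropylpropyl would give, and how a hydroxyl group, an amine or a longer ether chain would behave at this place. These numbers also do not show which part of any compound is lost in the microsomes.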